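Azole replacement on the chain carbon of the shared core

The source may report more compounds than this note shows. Statements on the series, on what has been measured and on what is new or still open speak of the compounds shown alone.

Measured compounds:
compound 1, `CC(C)C(Cc1nnc[nH]1)c1ccc(-c2ccc3cccc(F)c3c2)[nH]c1=O`, 10 nM in an assay on CHO cells for displacement of a labelled ligand from prostaglandin E2 receptor EP3 subtype (Homo sapiens), read by radioligand binding; on this read-out lower numbers stand for stronger inhibition and higher numbers for weaker inhibition
compound 2, `CC(C)C(c1nnc[nH]1)c1ccc(-c2ccc3cccc(F)c3c2)[nH]c1=O`, 12 nM in this assay
compound 3, `CC(C)C(Cc1noc(=O)[nH]1)c1ccc(-c2ccc3cccc(F)c3c2)[nH]c1=O`, 34 nM in this assay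

Compound 3 stands highest of the three numbers in this assay; its nearest neighbour is compound 2 (a 2.8-fold higher number from compound 2 to compound 3 (0.45 log units; beyond the scatter)), the furthest compound 1 (a 3.4-fold higher number from compound 1 to compound 3 (0.53 log units; beyond the scatter)). Compound 4, `Cc1c[nH]c(C(c2ccc(-c3ccc4cccc(F)c4c3)[nH]c2=O)C(C)C)n1`, is not yet measured. It differs from compound 3 in one place: a group of 6 heavy atoms (4 carbon, 2 nitrogen; one five-membered aromatic ring with 2 hetero atoms) in place of a group of 7 heavy atoms (3 carbon, 2 nitrogen, 2 oxygen; one five-membered aromatic ring with 3 hetero atoms), on a saturated chain carbon bound to an aromatic carbon and a saturated chain carbon. The change thus puts a five-membered aromatic ring with 2 hetero atoms directly on the chain carbon, as in compound 2, whose ring is also directly attached. Among the compounds with values here, the steps that bear on it are a 2.8-fold higher number from compound 2 to compound 3 (0.45 log units; beyond the scatter) and a 3.4-fold higher number from compound 1 to compound 3 (0.53 log units; beyond the scatter), both modest and both moving away from compound 3 toward lower numbers. A step of similar size back toward the numbers of compound 1 and compound 2 is expected in this assay. Compound 4 is therefore estimated at 15 nM, range 5 nM to 45 nM, an expected step of a 2.3-fold lower number from compound 3 to compound 4 (0.36 log units; beyond the scatter).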

Compound 4, inhibition constant: 12 nM
For compound 4 the middle estimate is 1.3-fold (0.10 log units) above the measured one, and the stated range covers the measured number.
By their numbers in this assay, from the lowest: compounds 1, 2 and 4 (each within the scatter of the next); then compound 3.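

In this assay, placing 4-methyl-1H-imidazol-2-yl on the saturated chain carbon gives a 2.8-fold lower number from compound 3 to compound 4 (0.45 log units; beyond the scatter), while no change at the digits printed from compound 2 to compound 4 (within the scatter) and a 1.2-fold higher number from compound 1 to compound 4 (0.08 log units; within the scatter) both stay within the scatter. This position therefore tolerates a five-membered aromatic ring with 2 hetero atoms and a methyl group as well as it tolerates either triazole attachment, leaving compound 3 as the only one of the four set apart by a step beyond the scatter. Nothing available explains why compound 3 stands apart.

As far as these compounds go, the effect of the methyl group stays open, as does what an unsubstituted 1H-imidazol-2-yl or a carboxylic acid would give on this chain carbon. From the compounds shown here alone, it is also open whether (4-methyl-1H-imidazol-2-yl)methyl would match the directly attached ring, as the two triazole attachments do.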